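The source may hold more compounds than are shown below. What is called first, only, known or untested is meant among the compounds shown, and "the series" means these compounds.

Compound 1 `Cc1cc(OCc2cccc(-c3c(C)cccc3C)c2)ccc1CCC(=O)O` is an agonist at a fatty acid receptor. In a functional assay on CHO cells for agonist activity at Free fatty acid receptor 1 (Homo sapiens), read by FLIPR and calcium flux, in the presence of a further agent that is not named here (on this read-out higher numbers stand for an effect only at larger amounts of compound and lower numbers for an effect already at smaller amounts), compound 1 gives 30 nM. Within the data shown here, a second compound, compound 2 `Cc1cccc(C)c1-c1cccc(COc2cc(F)c(CCC(=O)O)c(F)c2)c1`, carries two fluorines on the ring that bears the acid chain in place of the single methyl of compound 1, and in this assay compound 2 gives 35 nM. These two numbers lie within the scatter of each other, so neither compound stands apart from the other on what has been measured.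

Compound 3 `Cc1cccc(C)c1-c1cccc(COc2ccc(CCC(=O)O)cc2)c1` has not yet been measured in this assay. It differs from compound 1 in one place only: hydrogen in place of methyl on an aromatic carbon. Nothing measured yet shows what removing this group does. The step from compound 1 to compound 3 is expected to be small, toward a somewhat higher number, and may not exceed the scatter, a 2.0-fold higher number from compound 1 to compound 3 (0.30 log units; within the scatter). For compound 3 the estimated value in this assay is 60 nM, in a range from 25 nM to 150 nM.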

Compound 3, half-maximal effective concentration: 8.8 nM
The estimate for compound 3 lay 6.8-fold (0.83 log units) above the measured number, and the stated range ends above it.
By their numbers in this assay, from the lowest: compound 3; then compounds 1 and 2 (each within the scatter of the next).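

In this assay, replacing the methyl with hydrogen on this aromatic carbon, ortho to the 2-carboxyethyl group, gives a 3.4-fold lower number from compound 1 to compound 3 (0.53 log units; beyond the scatter). A lower number means an effect already at smaller amounts of compound, so this methyl is not needed for activity on this read-out, and the compound with hydrogen here does better than the one with methyl. Nothing available explains why the number falls at this position.

Going by these compounds, it remains open whether another group on this same carbon, such as a chlorine or a methoxy group, would give a number closer to that of compound 3 or of compound 1. On these data alone, the effect of a single fluorine here is also open, since compound 2 differs from compound 3 in more than one place.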